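The compounds below may be only part of what the source reports. "The series", "measured", "known", "first", "only" and "open" are said of these compounds alone.

Measured so far in an assay on C6 glioma cells for displacement of a labelled ligand from sodium- and chloride-dependent glycine transporter 1 (Rattus norvegicus), read by scintillation counting, with stated times of 30 min and 10 min; a lower number here means a stronger inhibitor, a higher number a weaker inhibitor:
- compound 1, `Cc1nnc(-c2ccc(-c3ccncc3)cc2)n1-c1ccccc1F`: compound 1 gives 5900 nM
- compound 2, `CCc1nnc(-c2ccc(-c3ccccc3)cn2)n1-c1ccccc1F`: compound 2 gives 700 nM
- compound 3, `CCc1nnc(-c2ccc(-c3ccccc3)cc2)n1-c1cccc(CO)c1C`: compound 3 gives 250 nM

Compound 3 shows the lowest number of the three in this assay. Its distance to compound 2 lies beyond the scatter, and its distance to compound 1 lies further beyond it, so compound 3 is the strongest inhibitor of the set as measured. Among the compounds with values here, no two of the measured compounds differ in a single place, so no step between them can be read off, and nothing in the set bears directly on the change now under consideration.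

Compound 4, `CCc1nnc(-c2ccc(-c3ccccc3)cc2)n1-c1cccc(C(=O)OC)c1C`, is derived from compound 3 by the change (methoxycarbonyl in place of hydroxymethyl on an aromatic carbon). Within the data shown here, the set holds no precedent for this exchange; a hydroxymethyl and a methoxycarbonyl on that position have not been compared anywhere here. The change is expected to cost little, a modest weakening at most, as the step of a 1.8-fold higher number from compound 3 to compound 4 (0.26 log units; within the scatter) is meant to express. For compound 4 the estimate in this assay is 450 nM, with a range from 150 nM to 1400 nM.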

Compound 4, half-maximal inhibitory concentration: 5100 nM
Estimate against measurement, compound 4: 11-fold (1.05 log units) below; the measured number lies above the stated range.
By their numbers in this assay, from the lowest: compound 3; then compound 2; then compounds 4 and 1 (each within the scatter of the next).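

In this assay, the position on the aromatic carbon ortho to a methyl group proves sensitive to what it carries: methoxycarbonyl in place of hydroxymethyl gives a 20-fold higher number from compound 3 to compound 4 (1.31 log units; beyond the scatter), a large step. Within the data shown here, this is the only single-place step in the set, and compounds 1 and 2 gave no reading of this position. The exchange alters several things at once, with hydrogen-bond donors going from 1 to 0 and heavy atoms from 2 to 4, and no measurement at hand explains the rise in the number.

Which of these differences carries the step remains open. Also open, as far as these compounds go, is whether a carboxylic acid, a primary amide or a methoxymethyl group at this place would read closer to compound 3 or to compound 4.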